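The source may hold more compounds than are shown below. What is called first, only, known or untested is meant among the compounds shown, and "the series" means these compounds.

Measured compounds in a functional assay on DU-145 cells (Homo sapiens) for inhibition; a lower number here means a stronger inhibitor, a higher number a weaker inhibitor:

Compound 1 `Oc1cccc(-c2cc(-c3cccc(F)c3)cc(-c3ccccc3O)n2)c1` — > 50000 nM, a limit of this assay, not a number.
Compound 2 `Oc1cccc(-c2cc(-c3ccc(F)cc3)cc(-c3ccccc3O)n2)c1` — > 50000 nM, likewise a limit of this assay.
Compound 3 `Oc1ccc(-c2cc(-c3cccc(F)c3)cc(-c3cccc(O)c3)n2)cc1` — 2700 nM.

Two of the three values sit at a limit, see (the limit of > 50000 nM in this assay, at which 2 of the 3 values shown sit). From compound 1 to compound 2 the change is 4-fluorophenyl in place of 3-fluorophenyl on an aromatic carbon, and the step is a step that the two limits leave unreadable from compound 1 to compound 2. Among the compounds with values here, from compound 1 to compound 3 the change is 4-hydroxyphenyl in place of 2-hydroxyphenyl on an aromatic carbon, and the step is an at least 18-fold lower number from compound 1 to compound 3 (1.26 log units; beyond the scatter); this is the only step in this assay that can be read.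

Compound 4 `Oc1ccc(-c2cc(-c3ccc(F)cc3)cc(-c3cccc(O)c3)n2)cc1` is not yet measured. It differs from compound 3 by 4-fluorophenyl in place of 3-fluorophenyl on an aromatic carbon. This is the same kind of change as from compound 1 to compound 2, but the surroundings differ: there the place was meta to a 2-hydroxyphenyl group and meta to a 3-hydroxyphenyl group, here it is meta to a 3-hydroxyphenyl group and meta to a 4-hydroxyphenyl group. The earlier step gave no readable size, so the expectation rests on compound 3 alone with its value 2700 nM, and the step from compound 3 to compound 4 is expected to be a 1.1-fold higher number from compound 3 to compound 4 (0.05 log units; within the scatter). Compound 4 is expected near 3000 nM, within 900 nM to 12000 nM.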

Compound 4, half-maximal inhibitory concentration: 15200 nM
Beside the measured number, compound 4's estimate is 5.1-fold (0.70 log units) below it, and the stated range ends below it.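

In this assay, 4-fluorophenyl in place of 3-fluorophenyl gives a 5.6-fold higher number from compound 3 to compound 4 (0.75 log units; beyond the scatter), the only readable size for this change; the same change from compound 1 to compound 2 cannot be read, as both values are limits of the assay: the limit of > 50000 nM in this assay, at which 2 of the 4 values shown sit.

Whether the fluorine shift carries from one core to the other is therefore not shown, neither in direction nor in size. The change from 2-hydroxyphenyl to 4-hydroxyphenyl does carry in direction, now with an at least 3.2-fold lower number from compound 2 to compound 4 (0.51 log units; beyond the scatter), but its size on the two cores cannot be compared: the same change on two cores in this assay, an at least 18-fold lower number (1.26 log units; beyond the scatter) from compound 1 to compound 3 and an at least 3.2-fold lower number (0.51 log units; beyond the scatter) from compound 2 to compound 4; the limit leaves it open whether they differ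

The compounds shown leave open how the fluorine shift behaves on a core with a 2-hydroxyphenyl group once values fall inside the range of the assay. They also leave open how the series responds when a chlorine takes the place of the fluorine, or when a methoxy group or an amine takes the place of a hydroxyl.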